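A few compounds are considered here, and "the series" means these few. Any claim that something is new, unique, unknown or untested is made for them only; others in the source may bear on it.

Measured in a functional assay on K562 cells (Homo sapiens) for cytotoxicity, read by sulforhodamine B assay; on this read-out higher numbers stand for lower toxicity in this test and lower numbers for higher toxicity in this test:
- Compound 1 `CC1=CC[C@@H]([C@@](C)(O)CCCC(C)(C)NC(=S)N/N=C\c2ccc(N(C)C)cc2)CC1`: > 100000 nM, a limit of the assay rather than a number.
- Compound 2 `CC1=CC[C@@H]([C@@](C)(O)CCCC(C)(C)NC(=S)N/N=C\c2cccc([N+](=O)[O-])c2)CC1`: 12600 nM.

Going by the values given here, compound 2, at 12600 nM, holds the only true number so far, so it cannot yet be ranked against a spread of values. Among the compounds with values here, its only comparison is with compound 1, whose result is a limit.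

The next compound, compound 3 `CC1=CC[C@@H]([C@@](C)(O)CCCC(C)(C)NC(=S)N/N=C\c2ccc(Cl)cc2)CC1`, has 4-chlorophenyl in place of 3-nitrophenyl on a carbon with a double bond to nitrogen.

Within the data shown here, only one measured step changes this same place: an at least 7.9-fold lower number from compound 1 to compound 2 (0.89 log units; beyond the scatter). It shows that the group here can shift the result in this assay. However, that step involves neither the group entering now nor a closed value at both ends, and no measured compound carries 4-chlorophenyl. It therefore gives no direction for this change, and the expectation stays anchored on compound 2 at 12600 nM, with wide margins.

The expected change is a 1.1-fold lower number from compound 2 to compound 3 (0.06 log units; within the scatter), and no step beyond the scatter is predicted. For compound 3 the estimated value is 11000 nM, with an expected range from 3000 nM to 40000 nM.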

Compound 3, concentration lethal to 50% of the cells: 10300 nM
Beside the measured number, compound 3's estimate is 1.1-fold (0.03 log units) above it; measured number inside the range.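

In this assay, the step of a 1.2-fold lower number from compound 2 to compound 3 (0.09 log units; within the scatter) shows that this position can take either 3-nitrophenyl or 4-chlorophenyl without a change that stands out from the scatter. Going by these compounds alone, the earlier comparison showed only that the group on this carbon can matter; this one shows that two different rings, one bearing a nitro group and the other a chlorine, can give results that cannot be told apart in this test. The second step, an at least 9.7-fold lower number from compound 1 to compound 3 (0.98 log units; beyond the scatter), points the same way as the first, so compound 1, with its 4-(dimethylamino)phenyl, now stands apart from two compounds rather than one.

On these data alone, because the nitro and chloro compounds differ in both the substituent and its ring position, the effect of each remains unresolved, and it is unknown how an unsubstituted phenyl, a 4-nitrophenyl, a 3-chlorophenyl or a ring bearing a carboxylic acid would behave here. Compound 1 gives > 100000 nM as a limit and not a number, so the full size of its gap to the others stays open: the limit of > 100000 nM in this assay, at which 1 of the 3 values shown sits.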